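The compounds below may be only part of what the source reports. "The series", "measured", "known", "first", "only" and "open" are said of these compounds alone.

Measured so far:
Compound 1 `CC1=CC[C@@H]([C@@](C)(O)CCCC(C)(C)NC(=S)N/N=C\c2ccc(N(C)C)cc2)CC1` gives > 100000 nM in a functional assay on PCO3 cells (Homo sapiens) for cytotoxicity, read by sulforhodamine B assay; on this read-out higher numbers stand for weaker inhibition of growth and lower numbers for stronger inhibition of growth; this is a limit of the assay, not a number.
Compound 2 `CC1=CC[C@@H]([C@@](C)(O)CCCC(C)(C)NC(=S)N/N=C\c2ccccc2[N+](=O)[O-])CC1` gives > 100000 nM in this assay; this too is a limit, not a number.

Compound 2 therefore stands at the limit of > 100000 nM in this assay, at which 2 of the 2 values shown sit, with no number of its own. Going by the values given here, the one measured step, a step that the two limits leave unreadable from compound 1 to compound 2, runs between two limits and its size cannot be read.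

Compound 3 `CC1=CC[C@@H]([C@@](C)(O)CCCC(C)(C)NC(=S)N/N=C\c2ccc(Cl)cc2)CC1` differs from compound 2 in one place: 4-chlorophenyl in place of 2-nitrophenyl on a carbon with a double bond to nitrogen. Among the compounds with values here, the only step that bears on this change is the one from compound 1 to compound 2, and it gives no readable size and no direction, so nothing points to a change beyond the scatter in this assay.

Compound 3 is accordingly expected near the same limit, at an estimated 100000 nM (range 20000 nM to 300000 nM). The expected step of a number no higher from compound 2 to compound 3 (the limit leaves the size open) is thus essentially none, with a further limit the most likely outcome for compound 3.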

Compound 3, concentration for total growth inhibition: 22700 nM
Compound 3: the middle estimate sits 4.4-fold (0.64 log units) above what was measured, within the range that was stated.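

In this assay the group on the carbon with a double bond to nitrogen can move the read-out off the limit, which the first two compounds could not show: 4-chlorophenyl gives an at least 4.4-fold lower number from compound 2 to compound 3 (0.64 log units; beyond the scatter), and chloro in place of dimethylamino on an aromatic carbon gives an at least 4.4-fold lower number from compound 1 to compound 3 (0.64 log units; beyond the scatter). Both sizes are lower bounds only, and the step between compound 1 and compound 2 still cannot be read. Compound 3 is the only one of the three with a number rather than a limit: the limit of > 100000 nM in this assay, at which 2 of the 3 values shown sit.

From the compounds shown here alone, whether the gain belongs to chloro itself stays open, and a bromo or methyl group in its place, or a plain phenyl, would bear on that. Also open, going by these compounds, is how much the hydroxyl group of the shared core contributes to the value of compound 3.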